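This account rests on a few compounds, and the source may have more. Where it says the series, first, only, none or still open, it means among the compounds named here.

In a functional assay on MCF7 cells (Homo sapiens) for antiproliferative activity, read by MTT assay, with a stated time of 24 h (on this read-out higher numbers stand for weaker inhibition and lower numbers for stronger inhibition), compound 1 `CCn1c(C(=O)N[C@H](C)C(=O)O)ccc1C(CC)(CC)c1ccc(OCS(=O)(=O)c2ccccc2)c(C)c1` gives > 50000 nM, which is a limit of the assay and not a number. Compound 2 `CCn1c(C(=O)NCCC(=O)O)ccc1C(CC)(CC)c1ccc(OCS(=O)(=O)c2ccccc2)c(C)c1` gives > 50000 nM, which is also a limit and not a number. Among the compounds with values here, compound 2 therefore stands at the same limit as the only other measured compound: the limit of > 50000 nM in this assay, at which 2 of the 2 values shown sit. Within the data shown here, the one measured step is a step that the two limits leave unreadable from compound 1 to compound 2, so it offers no size to carry forward. Compound 3 `CCn1c(C(=O)N[C@@H](CC(=O)O)C(=O)O)ccc1C(CC)(CC)c1ccc(OCS(=O)(=O)c2ccccc2)c(C)c1` brings a further change, carboxy in place of hydrogen on a saturated chain carbon bound to an amide-type nitrogen and a saturated chain carbon, turning 2-carboxyethyl to 1,2-dicarboxyethyl. Neither measured compound shows readable activity in this assay, so no clear gain is expected, and a further limit is the likely report. The expected step is a step that the limit leaves unreadable from compound 2 to compound 3. The estimated value for compound 3 is 70000 nM, with an expected range from 30000 nM to 150000 nM.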

Compound 3, half-maximal inhibitory concentration: > 50000 nM
Compound 3: a limit, no number (the forecaster's own chance of this, stated with the estimate: 90%); the middle value does not contradict the limit.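

Within the data shown here, compound 3 also gives a limit and not a number in this assay, so no step among compound 1, compound 2 and compound 3 can be read: the limit of > 50000 nM in this assay, at which 3 of the 3 values shown sit. The compounds shown leave open whether any change in this side chain brings a readable inhibition.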